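A Fluorine Added to the Benzyl Ring of Compound 3

The source may hold more compounds than are shown below. What is called first, only, known or untested is meant among the compounds shown, and "the series" means these compounds.

Compound 1 `Cc1ccc(NC(=S)NC(=O)c2ccc(OCc3ccc(C(F)(F)F)cc3)cc2)cc1-c1nc2ccccc2[nH]1`: 6500 nM
Compound 2 `Cc1ccc(NC(=S)NC(=O)c2ccc(OCc3ccc(Cl)cc3Cl)cc2)cc1-c1nc2ccccc2[nH]1`: 3450 nM
Compound 3 `Cc1ccc(NC(=O)NC(=O)c2ccc(OCc3ccccc3)cc2)cc1-c1nc2ccccc2[nH]1`: 39400 nM

All three share a core and were tested in a functional assay on MGC-803 cells (Homo sapiens) for inhibition, read by MTT assay, with a stated time of 48 h; a higher number here means a weaker inhibitor, a lower number a stronger inhibitor. Compound 3 stands highest of the three numbers, with 39400 nM in this assay, and both compound 1 and compound 2 sit below it by more than the scatter. Compound 4 `Cc1ccc(NC(=O)NC(=O)c2ccc(OCc3ccccc3F)cc2)cc1-c1nc2ccccc2[nH]1` keeps everything of compound 3 except one change: fluoro in place of hydrogen on an aromatic carbon. Going by the values given here, only one measured step touches this part of the molecule, a 1.9-fold lower number from compound 1 to compound 2 (0.28 log units; within the scatter), which exchanges one substituted benzyl group for another and stays within the scatter. Among the compounds with values here, no measured step adds fluoro to an otherwise unsubstituted phenyl. A change of no more than the scatter is therefore expected. Compound 4 is estimated at 30000 nM, within a range from 12000 nM to 80000 nM. The expected step is a 1.3-fold lower number from compound 3 to compound 4 (0.12 log units; within the scatter).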

Compound 4, half-maximal inhibitory concentration: 2520 nM
Compound 4: the middle estimate sits 12-fold (1.08 log units) above what was measured; measured number below the stated range.
By their numbers in this assay, from the lowest: compounds 4, 2 and 1 (each within the scatter of the next, the first and the last beyond it); then compound 3.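

In this assay, turning benzyl into 2-fluorobenzyl gives a 16-fold lower number from compound 3 to compound 4 (1.19 log units; beyond the scatter), a large step. This place on the ring is therefore far from indifferent: one added fluorine atom, on an aromatic carbon ortho to a large group, is enough to move the number well beyond the scatter. Nothing measured here accounts for the size of this step. The compounds shown leave open whether fluoro is special at this carbon or whether a methoxy group or an amine there would give a similar step. They also leave open what fluoro would do elsewhere on this ring.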